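A few compounds are considered here, and "the series" means these few. Any claim that something is new, unique, unknown or untested is made for them only; others in the source may bear on it.

In a functional assay on the whole organism (Hindlimb, strain albino) with Mus musculus as the target, in the maximal electroshock model, with a stated time of 0.5 h (a higher number here means that more compound is needed for the effect, a lower number that less compound is needed), compound 1 (`CC(=O)N1N=C(Nc2nc3ccc(Cl)cc3s2)CC1c1ccccc1`) gives 161 umol/kg as its dose for half-maximal effect, compound 2 (`CC(=O)N1N=C(Nc2nc3ccc(C)cc3s2)CC1c1ccccc1`) gives 106 umol/kg with methyl in place of the chloro, and compound 3 (`CC(=O)N1N=C(Nc2nc3ccc([N+](=O)[O-])cc3s2)CC1c1ccccc1`) gives 216 umol/kg with nitro in that place. Compound 1 stands within the scatter of both others: the data show a 1.5-fold lower number from compound 1 to compound 2 (0.18 log units; within the scatter) and also a 1.3-fold higher number from compound 1 to compound 3 (0.13 log units; within the scatter) as its two steps. Only a 2.0-fold higher number from compound 2 to compound 3 (0.31 log units; beyond the scatter) passes beyond the scatter, and it does so modestly.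

Compound 4 (`COc1ccc(C2CC(Nc3nc4ccc(Cl)cc4s3)=NN2C(C)=O)cc1`) keeps the chloro and the shared core of compound 1 and alters the phenyl instead. The change is methoxy in place of hydrogen on an aromatic carbon and reads as phenyl to 4-methoxyphenyl, with methoxy in place of hydrogen on an aromatic carbon, para to a large group. None of the three measured steps touches the phenyl, so they bear on this change only indirectly, as a guide to size: among these compounds, a swap of one group on an aromatic carbon moved the number little. No step beyond the scatter is therefore expected in this assay, and the expected change is a 1.1-fold lower number from compound 1 to compound 4 (0.03 log units; within the scatter) in size. For compound 4 the estimated value is 150 umol/kg with an expected range of 70 umol/kg to 320 umol/kg for the measurement.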

Compound 4, dose for half-maximal effect: 93.3 umol/kg
Beside the measured number, compound 4's estimate is 1.6-fold (0.21 log units) above it; measured number inside the range.
By their numbers in this assay, from the lowest: compounds 4, 2, 1 and 3 (each within the scatter of the next, the first and the last beyond it).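

In this assay the change from phenyl to 4-methoxyphenyl gives a 1.7-fold lower number from compound 1 to compound 4 (0.24 log units; within the scatter) as the first step read on this ring rather than at the chloro place. It shows that, with the chloro and the rest of the shared core kept, methoxy can take the place of hydrogen on this aromatic carbon, para to a large group, without a step beyond the scatter, so this position joins the chloro place as one where a single swap has so far left the dose needed close to that of the parent compound. Nothing measured here bears on the reason for the size of this step.

The compounds shown leave open whether an amine, a carboxylic acid or a longer chain such as ethoxy in the same place would also stay within the scatter of compound 1, or would instead give a step beyond it. They also leave open whether methoxy at this position gives a step of similar size when methyl or nitro stands in place of the chloro.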